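Halogen change on the phenyl ring of compound 2

The source may hold more compounds than are shown below. What is called first, only, known or untested is meant among the compounds shown, and "the series" means these compounds.

Two members of this series have numbers in a functional assay on MCF7 cells (Homo sapiens) for antiproliferative activity, read by MTT assay, with a stated time of 24 h, tested at 25 uM (on this read-out lower numbers stand for a stronger effect and higher numbers for a weaker effect at the one concentration tested), so far. Compound 1 `OC(CCn1nc2c(Br)c(Br)c(Br)c(Br)c2n1)c1ccc(F)cc1` gives 101% in this assay. Compound 2 `OC(CCn1nc2c(Br)c(Br)c(Br)c(Br)c2n1)c1ccccc1` gives 99% in this assay. Going by the values given here, the single measured step, a number 2 percentage points lower from compound 1 to compound 2 (within the scatter), lies within the scatter. On the two numbers available, compound 2 holds the lower figure, but its gap to compound 1 is within the scatter, so no order between the two can be read from this assay.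

The next compound, compound 3 `OC(CCn1nc2c(Br)c(Br)c(Br)c(Br)c2n1)c1ccc(Cl)cc1`, differs from compound 2 in one place: chloro in place of hydrogen on an aromatic carbon. The change thus puts chloro on the aromatic carbon where the measured step exchanged fluoro for hydrogen. Among the compounds with values here, the only step that bears on it, a number 2 percentage points lower from compound 1 to compound 2 (within the scatter), was too small to count. With no step beyond the scatter at this position in the series, no movement beyond the scatter is expected in this assay for compound 3, and the step is estimated as no change at the digits printed from compound 2 to compound 3 (within the scatter). Compound 3 is therefore estimated at 99%, with a range from 88% to 110%.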

Compound 3, a percentage reported as activity, at one concentration (the size of the read-out at that concentration, not a potency): 96%
Compound 3: middle estimate off by 3 percentage points, on the high side, within the range that was stated.
By their numbers in this assay, from the lowest: compounds 3, 2 and 1 (each within the scatter of the next).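

In this assay, going by these compounds alone, phenyl to 4-chlorophenyl gives a number 3 percentage points lower from compound 2 to compound 3 (within the scatter) on the aromatic carbon para to a large group, and chloro in place of fluoro at that same carbon gives a number 5 percentage points lower from compound 1 to compound 3 (within the scatter) as the first direct comparison of two halogens there. Hydrogen, fluoro and chloro on this carbon now form a set of three whose numbers all stand within the scatter of one another, so a second halogen adds no step beyond the scatter and no order among compounds 1, 2 and 3 can be read. No other measurement on hand bears on this result.

The compounds shown leave open whether any group at this carbon other than hydrogen, fluoro or chloro, such as an amine, a carboxylic acid or a methoxy group, would give a step beyond the scatter. They also leave open how the read-out responds to changes elsewhere in the molecule, such as a longer chain between the core and the aromatic ring or a ketone in place of the hydroxyl group.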